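Working notes on compound 4 against compound 1

The source may report more compounds than this note shows. Statements on the series, on what has been measured and on what is new or still open speak of the compounds shown alone.

Measured so far in a functional assay on A-375 cells (Homo sapiens) for antiproliferative activity, read by CCK-8 assay, with a stated time of 72 h, tested at 2 uM; a lower number here means a weaker effect, a higher number a stronger effect of the compound at the concentration tested:
compound 1, `CN(C(=S)SCc1ccc(C(=O)Nc2ccccc2N)cc1)c1cccnc1`: 26.5%
compound 2, `Cc1ccc(N2CCN(C(=S)SCc3ccc(C(=O)Nc4ccccc4N)cc3)CC2)cc1`: 25.8%
compound 3, `Nc1ccccc1NC(=O)c1ccc(CSC(=S)N2CCN(c3ccccc3F)CC2)cc1`: 18.7%

Compound 1 holds the highest of the three numbers in this assay, but compound 2 and compound 3 both lie within the scatter of it, so no order among the three can be read. Among the compounds with values here, the only single-place step measured, a number 7.1 percentage points lower from compound 2 to compound 3 (within the scatter), concerns a change on an amine nitrogen in a ring and does not touch the position altered here.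

Compound 4, `CN(Cc1cccnc1)C(=S)SCc1ccc(C(=O)Nc2ccccc2N)cc1`, differs from compound 1 as follows: (pyridin-3-yl)methyl in place of pyridin-3-yl on an amide-type nitrogen

Within the data shown here, no measured step bears on this change, so the step of a number 0.5 percentage points lower from compound 1 to compound 4 (within the scatter) is expected to be none beyond the scatter. Compound 4 is therefore estimated at 26% in this assay, with a range from 12% to 40%.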

Compound 4, a percentage reported as inhibition, at one concentration (the size of the read-out at that concentration, not a potency): 39.4%
For compound 4 the middle estimate is 13.4 percentage points below the measured one; the range from low to high includes it.
By their numbers in this assay, from the lowest: compounds 3, 2 and 1 (each within the scatter of the next); then compound 4.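

In this assay, within the data shown here, the change to (pyridin-3-yl)methyl from pyridin-3-yl on the amide-type nitrogen gives a number 12.9 percentage points higher from compound 1 to compound 4 (beyond the scatter) and is the only step so far that lies beyond the scatter. Among these compounds, this position therefore responds to the group it carries, which the earlier compounds could not show, as none of their steps touched it. Nothing measured here explains the step.

From the compounds shown here alone, whether a longer chain such as (pyridin-3-yl)ethyl, or benzyl in place of (pyridin-3-yl)methyl, moves the number further remains open. Going by these compounds, because the read-out comes from one concentration, potency also remains open.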